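Adding a New Amino Substituent to the Strongest Compound

A few compounds are considered here, and "the series" means these few. Any claim that something is new, unique, unknown or untested is made for them only; others in the source may bear on it.

So far, three compounds have been tested in an assay on isolated protein for binding affinity to Leucine-rich repeat serine/threonine-protein kinase 2 (Homo sapiens), read by TR-FRET and LanthaScreen, with a stated time of 2 h; a higher number here means a weaker inhibitor, a lower number a stronger inhibitor. Compound 3 `C[C@@H]1CCCN1c1c(C#N)c2c(N)nccc2n1C` gives 0.8 nM in this assay, the lowest of the three numbers and therefore the strongest inhibitor of the set, since its steps to both other compounds lie beyond the usual scatter. Compound 1 `C[C@@H]1CCCN1c1c(C#N)c2c(N)nc(Nc3ccn(C)n3)cc2n1C` gives 6 nM in this assay, and compound 2 `Cn1c(-n2cccc2)c(C#N)c2c(N)ncnc21`, which rests on a different core, gives 239 nM.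

Compound 4 `C[C@@H]1CCCN1c1c(C#N)c2c(N)nc(Nc3cnn(C)c3)cc2n1C` is derived from compound 3 by a single change: (1-methyl-1H-pyrazol-4-yl)amino in place of hydrogen on an aromatic carbon. Going by the values given here, only one measured step bears on this change. Compound 1 carries the closely related group (1-methyl-1H-pyrazol-3-yl)amino at the same aromatic carbon, and removing it gives a 7.5-fold lower number from compound 1 to compound 3 (0.88 log units; beyond the scatter). Placing a similar group back at that position is therefore expected to raise the number in this assay by a modest amount; the new group is joined to its ring at a different atom, so the exact size is uncertain. Compound 4 is expected to give 4 nM in this assay, with a likely range from 1.5 nM to 12 nM. That corresponds to an expected step of a 5.0-fold higher number from compound 3 to compound 4 (0.70 log units; beyond the scatter).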

Compound 4, inhibition constant: 538 nM
The estimate for compound 4 lay 130-fold (2.13 log units) below the measured number; measured number above the stated range.
By their numbers in this assay, from the lowest: compound 3; then compound 1; then compound 2; then compound 4.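

In this assay, swapping 1-methyl-1H-pyrazol-3-yl for 1-methyl-1H-pyrazol-4-yl on the amino nitrogen gives a 90-fold higher number from compound 1 to compound 4 (1.95 log units; beyond the scatter), so these two groups, which differ only in the ring atom that carries the nitrogen, cannot be treated as interchangeable at this position. Putting (1-methyl-1H-pyrazol-4-yl)amino in place of hydrogen on this aromatic carbon, next to the ring nitrogen, gives a 670-fold higher number from compound 3 to compound 4 (2.83 log units; beyond the scatter), while the earlier pair showed a much smaller difference between hydrogen and the 3-yl group, with a 7.5-fold lower number from compound 1 to compound 3 (0.88 log units; beyond the scatter). Substitution at this carbon is therefore not a matter of a fixed, modest penalty, since the result depends strongly on how the pyrazole is joined, and nothing available explains why the two joined forms part so sharply.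

On these data alone, whether a smaller methylamino group or a phenylamino group on this carbon would fall nearer compound 3 or nearer compound 4 remains open. Also open, as far as these compounds go, is whether the same sharp difference would persist in the pyrazole without its methyl group, as 1H-pyrazol-4-ylamino and 1H-pyrazol-3-ylamino.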